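This account rests on a few compounds, and the source may have more. Where it says the series, first, only, none or still open, it means among the compounds named here.

Measured compounds:
- compound 1 `Cc1cc(-c2ccnc(C(F)F)c2)ncc1OC[C@@](C)(N)CC(C)C`: 80%
- compound 2 `COC(=O)Nc1cc(-c2cc(Cl)c(OC[C@@](C)(N)CC(C)C)cn2)ccn1`: 87%
- compound 3 `COC(=O)Nc1cc(-c2cnc(OC[C@@](C)(N)CC(C)C)c(OC)c2)ccn1`: 59%

In an ADME assay on microsomes from liver (Mus musculus) for metabolic stability, read by LC-MS, using NADPH, with a stated time of 10 min, tested at 0.5 uM (a higher number here means that more of the compound is left, a lower number that less of the compound is left), compound 3 gives 59%, the lowest of the three numbers. Compound 1 gives 80%, above it beyond the scatter, and compound 2 gives 87%, the furthest from compound 3 and also beyond the scatter.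

Compound 4 `COC(=O)Nc1cc(-c2cnc(OC[C@@](C)(N)CC(C)C)c(C#N)c2)ccn1` differs from compound 3 in one place: cyano in place of methoxy on an aromatic carbon. Among the compounds with values here, no pair of measured compounds shows this change, so its size is not anchored by data. The step is expected to be small and upward, a number 7 percentage points higher from compound 3 to compound 4 (within the scatter), probably within the scatter. Compound 4 is estimated at 66%, with a range from 48% to 84%.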

Compound 4, percent of the compound remaining: 86%
Compound 4: the middle estimate sits 20 percentage points below what was measured; the measured number lies above the stated range.
By their numbers in this assay, from the lowest: compound 3; then compounds 1, 4 and 2 (each within the scatter of the next).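

At this position, ortho to a (2-amino-2,4-dimethylpentyl)oxy group and two atoms from the ring nitrogen, the group present clearly matters in this assay. Cyano in place of methoxy gives a number 27 percentage points higher from compound 3 to compound 4 (beyond the scatter), the only one-place comparison in the series so far. No measurement shown accounts for this step.

Open, going by these compounds, is how an amine, a fluorine or a longer ether chain at the same position would read. Also open, on these data alone, is whether the change gives a similar step on another core.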